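Aryl group swap on the shared core: efficacy notes

This account rests on a few compounds, and the source may have more. Where it says the series, first, only, none or still open, it means among the compounds named here.

For the measured compounds named here, compound 1 `O=C(O)Cc1sc(C(c2ccccc2)c2ccccc2)nc1-c1ccc(F)cc1` and compound 2 `CS(=O)(=O)Nc1cccc(-c2nc(C(c3ccc(F)cc3)c3ccc(F)cc3)sc2CC(=O)O)c1` are the two measured members. In an in vitro functional assay on HEK285-7 cells for antagonist activity at prostaglandin D2 receptor 2 (Homo sapiens), read by BRET and beta-arrestin recruitment (a higher number here means a larger maximal response, a lower number a smaller maximal response), compound 1 gives 80%. In this assay compound 2 gives 80%, level with compound 1 at the digits shown; the pair lies within the scatter, so the two values show no difference between them. Compound 3 `O=C(O)Cc1sc(C(c2ccc(F)cc2)c2ccc(F)cc2)nc1-c1ccncc1` has not yet been measured. It differs from compound 2 in one place: pyridin-4-yl in place of 3-(methanesulfonamido)phenyl on an aromatic carbon. Going by the values given here, no step between measured compounds is available, so any expectation for this change in this assay rests on the value of compound 2 alone and on the fact that the measured values sit close together. The estimate is a small downward step, or none beyond the scatter: the step of a number 5 percentage points lower from compound 2 to compound 3 (within the scatter) is expected to stay within the usual scatter. Compound 3 is accordingly expected to reach 75% in this assay, with the estimate spanning 55% to 90%. Nothing in the measured series shows how the entering group behaves, so the range is kept wide.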

Compound 3, largest response reached (reported as efficacy), in percent of the reference or control that the assay uses: 80%
Estimate against measurement, compound 3: 5 percentage points below; the measured number falls inside the stated range.
By their numbers in this assay, from the lowest: compounds 1, 2 and 3 (each within the scatter of the next).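

Swapping 3-(methanesulfonamido)phenyl for pyridin-4-yl, on the aromatic carbon next to the ring nitrogen and next to the ring atom that bears a carboxymethyl group, gives no change at the digits printed from compound 2 to compound 3 (within the scatter) in this assay; this is the first step in the series that can be read at a single place. At this position, the largest response reached therefore stays level when a phenyl group carrying the methanesulfonamido substituent, with its hydrogen-bond donor, gives way to a ring that has one ring nitrogen and no hydrogen-bond donor, so for this pair the methanesulfonamido group is not needed to hold that read-out. No supporting measurement is available to explain this result.

The compounds shown leave open whether this level holds for other groups on the same aromatic carbon, such as an aliphatic amine, a morpholine ring or a longer alkyl chain, since a single step cannot show how far the position tolerates change. For the compounds shown here, they also give no single-place step at the ring atom that bears a large group or at the carboxymethyl group, so the response to changes at those two places remains unknown.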